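Swapping dichlorophenyl patterns on a shared enone core

The source may report more compounds than this note shows. Statements on the series, on what has been measured and on what is new or still open speak of the compounds shown alone.

Compound 1, `COc1cc(/C=C2\CN(C)C/C(=C\c3ccc(Cl)cc3Cl)C2=O)cc(OC)c1OC`, was tested in a functional assay on K562 cells (Homo sapiens) for cytotoxicity, read by MTT assay, with a stated time of 24 h; a lower number here means a stronger inhibitor, a higher number a weaker inhibitor. For compound 1 the result is > 20000 nM, a limit of the assay rather than a number (the limit of > 20000 nM in this assay, at which 1 of the 3 values shown sits). Compound 2, `COc1cc(/C=C2\CN(C)C/C(=C\c3ccc(Cl)c(Cl)c3)C2=O)cc(OC)c1OC`, carries the same core but with one change: 3,4-dichlorophenyl in place of 2,4-dichlorophenyl on a double-bonded chain carbon bound to a double-bonded ring carbon. In this assay compound 2 gives 16200 nM, and the step is an at least 1.2-fold lower number from compound 1 to compound 2 (0.09 log units; that floor lies within the scatter).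

Compound 3, `CN1C/C(=C\c2cccc([N+](=O)[O-])c2)C(=O)/C(=C/c2ccc(Cl)cc2Cl)C1`, has a different core from compound 1; the difference between the two cores is not broken down here. In this assay compound 3 gives 12400 nM.

Compound 4, `CN1C/C(=C\c2cccc([N+](=O)[O-])c2)C(=O)/C(=C/c2ccc(Cl)c(Cl)c2)C1`, has not yet been measured. It stands to compound 3 as compound 2 stands to compound 1, through the same change: 3,4-dichlorophenyl in place of 2,4-dichlorophenyl on a double-bonded chain carbon bound to a double-bonded ring carbon. The step from compound 3 to compound 4 is expected to be a 1.2-fold lower number from compound 3 to compound 4 (0.09 log units; within the scatter), a guess resting on the earlier pair, where the step was an at least 1.2-fold lower number from compound 1 to compound 2 (0.09 log units; that floor lies within the scatter). Compound 4 is therefore estimated at 10000 nM, within a range from 4000 nM to 25000 nM.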

Compound 4, half-maximal inhibitory concentration: 15500 nM
For compound 4 the middle estimate is 1.6-fold (0.19 log units) below the measured one, and the stated range covers the measured number.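

On the core of compound 3, 3,4-dichlorophenyl in place of 2,4-dichlorophenyl gives a 1.3-fold higher number from compound 3 to compound 4 (0.10 log units; within the scatter) in this assay, so the swap has no readable effect on this core. Set beside the earlier pair, this step can be called neither the same nor different: the same change on two cores in this assay, an at least 1.2-fold lower number (0.09 log units; that floor lies within the scatter) from compound 1 to compound 2 and a 1.3-fold higher number (0.10 log units; within the scatter) from compound 3 to compound 4; the limit leaves it open whether they differ Compound 1 stands at a limit of the assay, > 20000 nM, and not at a number, so nothing here shows that the change carries from one core to the other, or that it fails to.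

The compounds shown leave open whether the swap would behave the same way with partners on the other side of the core beyond the trimethoxyphenyl and nitrophenyl groups seen here. They also leave open whether replacing the chlorines with a different group, such as an amine or a carboxylic acid, would move the number in this assay beyond the usual scatter.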